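This account rests on a few compounds, and the source may have more. Where it says the series, first, only, none or still open, it means among the compounds named here.

Two compounds share a core that carries an amino-benzamide and a purine-like unit with a chloro group, and differ only in the group on a nitrogen on an aromatic ring. Compound 1 `Nc1ccccc1NC(=O)c1ccc(Cn2cnc3c(Nc4ccccc4)nc(Cl)nc32)cc1` carries a phenyl there and gives 1070 nM in a functional assay on HCT-116 cells (Homo sapiens) for antiproliferative activity, read by CCK-8 assay, with a stated time of 72 h; a lower number here means a stronger inhibitor, a higher number a weaker inhibitor. Compound 2 `Nc1ccccc1NC(=O)c1ccc(Cn2cnc3c(NCc4ccccc4)nc(Cl)nc32)cc1` carries a benzyl there and gives 1060 nM in this assay. The step of a 1.0-fold lower number from compound 1 to compound 2 (0.00 log units; within the scatter) shows that swapping phenyl for benzyl left the number essentially where it was, so compound 2 and compound 1 stand side by side within the scatter.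

Compound 3 `Nc1ccccc1NC(=O)c1ccc(Cn2cnc3c(Nc4ccc(-c5ccccn5)cc4)nc(Cl)nc32)cc1` extends this series by the change (4-(pyridin-2-yl)phenyl in place of benzyl on a nitrogen on an aromatic ring). Among the compounds with values here, only the flat step from compound 1 to compound 2 bears on it, and no measured step covers an added pyridine ring, so a step of a 1.2-fold lower number from compound 2 to compound 3 (0.07 log units; within the scatter) in this assay is expected, without a direction beyond the scatter. Compound 3 is therefore estimated at 900 nM, within a range from 300 nM to 2700 nM.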

Compound 3, half-maximal inhibitory concentration: 1250 nM
Compound 3: middle estimate off by 1.4-fold (0.14 log units), on the low side; the range from low to high includes it.
By their numbers in this assay, from the lowest: compounds 2, 1 and 3 (each within the scatter of the next).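

Compound 3 puts a much larger group on this nitrogen than phenyl or benzyl, with a pyridine ring and a hydrogen-bond acceptor that neither of those has. Even so, this assay shows a 1.2-fold higher number from compound 2 to compound 3 (0.07 log units; within the scatter), and for pyridin-2-yl in place of hydrogen on an aromatic carbon it shows a 1.2-fold higher number from compound 1 to compound 3 (0.07 log units; within the scatter). Across these three compounds, then, the group at this position has grown considerably without any readable shift in the number, and nothing in the data at hand offers a reason for that flatness.

Still open, going by these compounds, is whether a different kind of group on this nitrogen, such as a carboxylic acid, a simple amine or a longer alkyl chain, would move the number beyond the scatter. The compounds shown also leave open whether any change elsewhere on the shared core, such as an amine in place of the chloro group, would do so.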